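A few compounds are considered here, and "the series" means these few. Any claim that something is new, unique, unknown or untested is made for them only; others in the source may bear on it.

Among the compounds with values here, compound 1 `CCNc1nc(Cl)nc(N[C@@H](C)c2ccccc2)n1` holds the higher of the two numbers so far in an ADME assay on the whole organism for inhibition, with Echinochloa crus-galli var. formosensis as the target, with a stated time of 4 days; on this read-out higher numbers stand for weaker inhibition and lower numbers for stronger inhibition: compound 1 gives 30900 nM, while compound 2 `CC(C)N(c1nc(Cl)nc(N[C@@H](C)c2ccccc2)n1)C(C)C` gives 110 nM. Within the data shown here, the only measured step, a 280-fold lower number from compound 1 to compound 2 (2.45 log units; beyond the scatter), is large, but it replaces ethylamino with diisopropylamino on an aromatic carbon and leaves the stereocentre as drawn. It shows how far this series can move, yet bears only loosely on the next comparison.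

Compound 3 `CCNc1nc(Cl)nc(NC(C)c2ccccc2)n1` keeps the ethylamino group: the two compounds have the same atoms and bonds; at least one stereo element is drawn with a configuration in one of them and without one in the other: 1 of 1 stereo elements differ; a stereocentre at a saturated chain carbon is drawn S in compound 1 and without a configuration in compound 3. Among the measured compounds shown here, no measured pair isolates this stereocentre, and no value exists for the opposite configuration. A step of the size seen with diisopropylamino is therefore not expected in this assay. For the measured compounds named here, a small move to a lower number is the working expectation, possibly not beyond the scatter, and it rests on compound 1 sitting at 30900 nM, the high end of the numbers so far.

For compound 3 the estimated value is 20000 nM, with an expected range of 5000 nM to 50000 nM. The expected change is a 1.5-fold lower number from compound 1 to compound 3 (0.19 log units; within the scatter).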

Compound 3, half-maximal inhibitory concentration: 9770 nM
For compound 3 the middle estimate is 2.0-fold (0.31 log units) above the measured one, and the stated range covers the measured number.
By their numbers in this assay, from the lowest: compound 2; then compound 3; then compound 1.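

With atoms and bonds unchanged, this assay still records a 3.2-fold lower number from compound 1 to compound 3 (0.50 log units; beyond the scatter), so the way the stereocentre at the saturated chain carbon is drawn goes with a difference that the read-out can resolve. Within the data shown here, this is the first reading on that stereocentre, and the step is much smaller than a 280-fold lower number from compound 1 to compound 2 (2.45 log units; beyond the scatter), which comes from changing the amino group on an aromatic carbon rather than the stereocentre. The ethylamino group, the chlorine and the rest of the core stay the same here, leaving one point of difference between the two entries: the fact that one of compounds 1 and 3 is drawn with a defined configuration and the other without, at the place where they differ

The drawing of compound 3 does not say which stereo forms it contains, and the opposite configuration at that carbon has no value of its own among the compounds shown, so the step cannot yet be assigned to one form or the other. Also open, from the compounds shown here alone, is whether the same stereocentre gives a step of this size alongside diisopropylamino, or with a smaller amine such as methylamino, or with a methoxy group in place of the chlorine.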